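Closing the amine: from compound 3 to compound 4

This account rests on a few compounds, and the source may have more. Where it says the series, first, only, none or still open, it means among the compounds named here.

In a functional assay on HL-60 cells (Homo sapiens) for inhibition, read by MTT assay, with a stated time of 48 h, tested at 10 uM (a higher number here means more inhibition of growth at the concentration tested, a lower number less inhibition of growth), compound 3 `CCN(CC)Cc1c(O)c([C@H]2CCN(C)C[C@H]2O)c2oc(C)cc(=O)c2c1O` gives 47%, the highest of the three numbers measured. Compound 2 `Cc1cc(=O)c2c(O)cc(OCc3ccco3)c([C@H]3CCN(C)C[C@H]3O)c2o1` gives 32% and compound 1 `Cc1cc(=O)c2c(O)cc(OCc3ccc(Br)cc3)c([C@H]3CCN(C)C[C@H]3O)c2o1` gives 27%, both beyond the scatter below compound 3. Among the measured compounds shown here, the only measured step, a number 5 percentage points higher from compound 1 to compound 2 (within the scatter), concerns a different place on the core and lies within the scatter, so it says little about the change in hand. Compound 4 `Cc1cc(=O)c2c(O)c(CN3CCCCC3)c(O)c([C@H]3CCN(C)C[C@H]3O)c2o1` differs from compound 3 by piperidin-1-yl in place of diethylamino on a saturated chain carbon bound to an aromatic carbon. For the measured compounds named here, no measured step bears on this change, so nothing in the data points to a move in either direction. Compound 4 is therefore expected at an estimated 46%, with a range from 32% to 60%. The expected step of a number 1 percentage points lower from compound 3 to compound 4 (within the scatter) is none beyond the scatter.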

Compound 4, percent growth inhibition at one concentration: 32%
Compound 4: middle estimate off by 14 percentage points, on the high side, and the stated range covers the measured number.
By their numbers in this assay, from the lowest: compounds 1, 2 and 4 (each within the scatter of the next); then compound 3.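

In this assay, piperidin-1-yl in place of diethylamino on a saturated chain carbon bound to an aromatic carbon gives a number 15 percentage points lower from compound 3 to compound 4 (beyond the scatter), so at this position the open diethylamino group and the ring are not interchangeable. The earlier compounds shown here offered no such comparison of two amines at this place. Nothing measured here explains the difference. Going by these compounds, whether a pyrrolidine ring, a morpholine ring or a dimethylamino group would read nearer to compound 3 or to compound 4 remains open.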